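From compound 2 to compound 3: one added methyl

The source may report more compounds than this note shows. Statements on the series, on what has been measured and on what is new or still open speak of the compounds shown alone.

Measured in a functional assay on SF-295 cells (Homo sapiens); on this read-out higher numbers stand for weaker inhibition of growth and lower numbers for stronger inhibition of growth:
- compound 1 `COc1ccc(-c2cc(O)c3cccnc3n2)cc1`: 64600 nM
- compound 2 `Oc1cc(-c2ccc(Cl)cc2)nc2ncccc12`: 40700 nM

In this assay, within the data shown here, compound 2 gives 40700 nM, which lies within the scatter of the value of compound 1, the only other compound measured. The two therefore cannot be told apart, and compound 2 stands level with compound 1 on these numbers.

The next compound is compound 3 `Cc1ccnc2nc(-c3ccc(Cl)cc3)cc(O)c12`, which differs from compound 2 on the shared core: methyl in place of hydrogen on an aromatic carbon. This is methyl in place of hydrogen on an aromatic carbon, opposite the ring nitrogen.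

Among the measured compounds shown here, only one measured step is available, a 1.6-fold lower number from compound 1 to compound 2 (0.20 log units; within the scatter). It stayed within the scatter, but it concerns chloro in place of methoxy, a change at another place. For the measured compounds named here, no measured compound carries the new methyl, so the data give no direction for this change. No shift beyond the scatter is therefore expected, although the uncertainty is wide.

The estimate is an expected 1.3-fold lower number from compound 2 to compound 3 (0.10 log units; within the scatter).

Compound 3 is expected to give 32000 nM, with an estimated range from 9000 nM to 90000 nM.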

Compound 3, concentration for 50% growth inhibition: 5370 nM
Compound 3: the middle estimate sits 6.0-fold (0.78 log units) above what was measured, outside the stated range (below it).
By their numbers in this assay, from the lowest: compound 3; then compounds 2 and 1 (each within the scatter of the next).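

In this assay, among these compounds, methyl in place of hydrogen on an aromatic carbon, opposite the ring nitrogen, gives a 7.6-fold lower number from compound 2 to compound 3 (0.88 log units; beyond the scatter) and so produces the only step here that lies beyond the scatter. The earlier step, a 1.6-fold lower number from compound 1 to compound 2 (0.20 log units; within the scatter), concerned chloro in place of methoxy at another place on the molecule and could not separate its two compounds, so this position is the first shown to matter for the read-out, and a single added carbon is enough to register there. Nothing available explains how the added methyl produces this shift, and no measurement bears on its cause.

With only hydrogen and methyl shown at this position, it remains open whether a longer chain such as ethyl, a halogen such as chloro, or an amine would extend the shift, leave it unchanged or reverse it. From the compounds shown here alone, it also remains open whether the methyl would produce a step of similar size alongside the methoxy group of compound 1 , since compound 3 carries it only with the chloro group.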